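Replacing the aryl amine substituent: a nitrophenyl analogue

The compounds below may be only part of what the source reports. "The series", "measured", "known", "first", "only" and "open" are said of these compounds alone.

The measured compounds in a functional assay on HGC-27 cells (Homo sapiens) for cytotoxicity, read by MTT assay, with a stated time of 72 h; a higher number here means a weaker inhibitor, a lower number a stronger inhibitor:
Compound 1 `CCCCCCCCNc1nc(SCc2ccc(C(F)(F)F)cc2)nc2ccccc12` gives 13400 nM.
Compound 2 `COc1ccccc1Nc1nc(SCc2ccc(C(F)(F)F)cc2)nc2ccccc12` reaches only a limit, > 50000 nM.
Compound 3 `Cc1ccccc1Nc1nc(SCc2ccc(C(F)(F)F)cc2)nc2ccccc12` gives 27500 nM.

Compound 3 stands highest of the two numbers; its nearest neighbour is compound 1, with a 2.1-fold higher number from compound 1 to compound 3 (0.31 log units; beyond the scatter). Compound 2 sits at a limit of the assay (the limit of > 50000 nM in this assay, at which 1 of the 3 values shown sits), and the step of an at least 1.8-fold lower number from compound 2 to compound 3 (0.25 log units; that floor lies within the scatter) therefore has a floor within the scatter. Compound 4 `O=[N+]([O-])c1cccc(Nc2nc(SCc3ccc(C(F)(F)F)cc3)nc3ccccc23)c1` is not yet measured; it differs from compound 3 by 3-nitrophenyl in place of 2-methylphenyl on a nitrogen on an aromatic ring. Both aryl amines so far gave weaker inhibition than the octyl chain of compound 1, and the methoxyphenyl ran to the limit. A further weakening is therefore expected, a 1.5-fold higher number from compound 3 to compound 4 (0.16 log units; within the scatter), possibly up to the limit. For compound 4 the estimate is 40000 nM, within 14000 nM to 50000 nM.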

Compound 4, half-maximal inhibitory concentration: > 50000 nM
Compound 4 gave a limit, no number; the forecaster's own chance of this, stated with the estimate: 45%; middle value at least 1.2-fold (0.09 log units) away from the limit.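

In this assay, compound 4 is the second aryl amine to end at a limit of the assay, after compound 2: the limit of > 50000 nM in this assay, at which 2 of the 4 values shown sit. With 3-nitrophenyl, the comparison with the octyl chain gives an at least 3.7-fold higher number from compound 1 to compound 4 (0.57 log units; beyond the scatter), so all three aryl amines now give higher numbers than compound 1, whereas the comparison with 2-methylphenyl gives an at least 1.8-fold higher number from compound 3 to compound 4 (0.25 log units; that floor lies within the scatter). The step between compound 2 and compound 4 cannot be read, as both values are limits.

As far as these compounds go, it remains open whether a chain longer than octyl, or a phenyl ring carrying a carboxylic acid, would give a lower number than compound 1. From the compounds shown here alone, the actual values of compound 2 and compound 4 also remain open.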